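The source may report more compounds than this note shows. Statements on the series, on what has been measured and on what is new or still open speak of the compounds shown alone.

Measured compounds:
- Compound 1 `COC(=O)c1cccc(CN(CCCC(N)=O)C[C@H]2O[C@@H](n3cnc4c(N)ncnc43)[C@H](O)[C@@H]2O)c1`. In an assay on cells for inhibition of Nicotinamide N-methyltransferase (Homo sapiens), with stated times of 10 min and 30 min (on this read-out higher numbers stand for weaker inhibition and lower numbers for stronger inhibition), compound 1 gives > 250000 nM, a limit of the assay and not a number.
- Compound 2 `COC(=O)c1cccc(CN(CCCCC(N)=O)C[C@H]2O[C@@H](n3cnc4c(N)ncnc43)[C@H](O)[C@@H]2O)c1`. In this assay compound 2 gives > 250000 nM, again a limit of the assay.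
- Compound 3 `COC(=O)c1cccc(CN(C[C@H]2O[C@@H](n3cnc4c(N)ncnc43)[C@H](O)[C@@H]2O)C(C)C)c1`. In this assay compound 3 gives > 250000 nM, also a limit of the assay.

Compound 2 therefore stands at the same limit as the other two; all three values sit at the limit of > 250000 nM in this assay, at which 3 of the 3 values shown sit, and none is a number that can be ordered against another.

Compound 4 `NC(=O)CCCCN(Cc1cccc(C(=O)O)c1)C[C@H]1O[C@@H](n2cnc3c(N)ncnc32)[C@H](O)[C@@H]1O` differs from compound 2 by hydrogen in place of methyl on an oxygen next to a carbonyl group; cut one bond further out this reads methoxycarbonyl to carboxy.

For the measured compounds named here, of the measured steps, a step that the two limits leave unreadable from compound 1 to compound 2, a step that the two limits leave unreadable from compound 1 to compound 3 and a step that the two limits leave unreadable from compound 2 to compound 3 all run between two limits and give no readable size; none of them touches the oxygen next to the carbonyl group, so no measured step bears directly on the change to compound 4.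

With compound 2 at a limit and no readable step in hand, compound 4 is expected to remain at or near that limit, an expected step that the limit leaves unreadable from compound 2 to compound 4 in this assay, not distinguishable from none. The estimate for compound 4 is 300000 nM, expected between 100000 nM and 1000000 nM, most likely reported again as a limit.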

Compound 4, half-maximal inhibitory concentration: > 250000 nM
Compound 4 was reported as a limit; the forecaster's own chance of this, stated with the estimate: 80%; the middle value is on the limit's open side.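

Compound 2 and compound 4 both stand at a limit of the assay, not a number, so the change from methoxycarbonyl to carboxy gives no readable step: the limit of > 250000 nM in this assay, at which 4 of the 4 values shown sit.

The compounds shown leave open how large that step is and which change, if any, would give a measurable value in this assay.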